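Replacing Dichlorophenyl with Fluorophenyl: Expected Vero Cell Tolerance

This account rests on a few compounds, and the source may have more. Where it says the series, first, only, none or still open, it means among the compounds named here.

Compound 1 `COC(=O)c1cc(-c2cccc(NC(=O)c3ccc(/C=C/C(=O)c4ccc(Cl)cc4Cl)cc3)c2)on1` is one of three compounds examined in an ADME assay on Vero cells (Chlorocebus sabaeus) for cytotoxicity, read by MTT assay, with a stated time of 72 h; a higher number here means that more compound is tolerated, a lower number that less compound is tolerated. In this assay compound 1 gives > 40 ug/mL, which is a limit of the assay and not a number. Compound 3 `CCOC(=O)c1cc(-c2cccc(NC(=O)c3ccc(/C=C/C(=O)c4ccc(Cl)cc4)cc3)c2)on1` also reaches only a limit, giving > 80 ug/mL in this assay. For compound 2 `CCOC(=O)c1cc(-c2cccc(NC(=O)c3cccc(C(F)(F)F)c3)c2)on1` the result in this assay is "not determined" (no result reported). Compound 1 therefore stands on a limit alone, beside one further limit and one entry without a number. Compound 4 `COC(=O)c1cc(-c2cccc(NC(=O)c3ccc(/C=C/C(=O)c4cccc(F)c4)cc3)c2)on1` differs from compound 1 by 3-fluorophenyl in place of 2,4-dichlorophenyl on a carbonyl carbon. For the measured compounds named here, no measured step covers this change, and in this assay no shift beyond the scatter is expected a step that the limit leaves unreadable from compound 1 to compound 4. Compound 4 is estimated at 60 ug/mL, within a range from 30 ug/mL to 120 ug/mL.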

Compound 4, half-maximal cytotoxic concentration: > 40 ug/mL
Compound 4: no number, only a limit; the forecaster's own chance of this, stated with the estimate: 70%; the middle value is on the limit's open side.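

Compound 1 and compound 4 both stop at a limit in this assay, so no step can be read between them. The compounds shown leave open whether 3-fluorophenyl in place of 2,4-dichlorophenyl changes tolerance at all.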